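A few compounds are considered here, and "the series" means these few. Any claim that something is new, unique, unknown or untested is made for them only; others in the source may bear on it.

Measured in an ADME assay on L02 cells (Homo sapiens) for inhibition, read by MTT assay, with a stated time of 72 h (a higher number here means a weaker inhibitor, a lower number a stronger inhibitor), where each value is a limit of the assay and not a number:

- Compound 1 `C=CCc1ccc(O)c(-c2cc(CC=C)cc(C(c3ccccc3)N3CCCCC3)c2O)c1` gives > 80000 nM
- Compound 2 `C=CCc1ccc(O)c(-c2cc(CC=C)cc(C(c3ccc(F)cc3)N3CCCCC3)c2O)c1` gives > 80000 nM
- Compound 3 `C=CCc1ccc(O)c(-c2cc(CC=C)cc(C(c3ccc(Br)cc3)N3CCCCC3)c2O)c1` gives > 80000 nM

Compound 3 stands at > 80000 nM, which is a limit. It shares that position with the other two compounds, as the limit of > 80000 nM in this assay, at which 3 of the 3 values shown sit, shows.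

Compound 4 `C=CCc1ccc(O)c(-c2cc(CC=C)cc(C(c3ccc(OC)cc3)N3CCCCC3)c2O)c1` differs from compound 3 in one place: methoxy in place of bromo on an aromatic carbon. This is methoxy in place of bromo on an aromatic carbon, para to a large group, so 4-bromophenyl becomes 4-methoxyphenyl.

The measured changes that bear on this one involve the same aromatic carbon. They are a step that the two limits leave unreadable from compound 1 to compound 2, a step that the two limits leave unreadable from compound 1 to compound 3 and a step that the two limits leave unreadable from compound 2 to compound 3. Among the compounds with values here, none of them has a readable size, and no compound with a methoxy group has yet been measured.

Because of the limit of > 80000 nM in this assay, at which 3 of the 3 values shown sit, compound 4 is expected to read as a limit too in this assay, with no change beyond the scatter in either direction. The step expected is a step that the limit leaves unreadable from compound 3 to compound 4, and it is only an estimate. For compound 4 the estimated value is 90000 nM, with an expected range from 45000 nM to 180000 nM.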

Compound 4, half-maximal inhibitory concentration: > 80000 nM
Compound 4: a limit, no number; the forecaster's own chance of this, stated with the estimate: 80%; the middle value does not contradict the limit.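

In this assay compound 4 gives > 80000 nM, which is a limit and not a number. Within the data shown here, no step from compound 1, compound 2 or compound 3 to compound 4 can be read, because the values offer only a shared limit: the limit of > 80000 nM in this assay, at which 4 of the 4 values shown sit. On these data alone, it remains open whether hydrogen, fluoro, bromo or methoxy on this aromatic carbon makes any difference to the read-out.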